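The source may report more compounds than this note shows. Statements on the series, on what has been measured and on what is new or still open speak of the compounds shown alone.

Measured so far in an ADME assay on L929 cells (Mus musculus) for cytotoxicity, read by resazurin assay, with a stated time of 72 h; on this read-out lower numbers stand for stronger inhibition and higher numbers for weaker inhibition

Compound 1 `O=C(/C=C/c1ccc2c(c1)B(O)OC2)c1ccc(C(F)(F)F)cc1` gives > 10 ug/mL
Compound 2 `O=C(/C=C/c1ccc2c(c1)B(O)OC2)c1ccc(F)cc1` gives > 10 ug/mL

Both entries are limits of the assay and not numbers. Compound 2 has no number of its own and stands only at the limit of > 10 ug/mL in this assay, at which 2 of the 2 values shown sit. Compound 3 `O=C(O)c1ccc(C(=O)/C=C/c2ccc3c(c2)B(O)OC3)cc1` differs from compound 2 by carboxy in place of fluoro on an aromatic carbon, para to a large group (carboxy in place of fluoro on an aromatic carbon). Within the data shown here, one measured step bears on this change, a step that the two limits leave unreadable from compound 1 to compound 2, and it has no readable size. No size can be carried over to the new change, so no step beyond the usual scatter is expected in this assay and no direction is favoured. Compound 3 is expected to stay near the limit, on the strength of the limit of > 10 ug/mL in this assay, at which 2 of the 2 values shown sit. The expected move is a step that the limit leaves unreadable from compound 2 to compound 3. For compound 3 the estimated value is 15 ug/mL, with an expected range from 7 ug/mL to 50 ug/mL.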

Compound 3, half-maximal inhibitory concentration: > 10 ug/mL
Compound 3: a limit, no number (the forecaster's own chance of this, stated with the estimate: 80%); the middle value is on the limit's open side.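

In this assay compound 3 gives only a limit and not a number, as compound 1 and compound 2 do, so no step from either to compound 3 can be read: the limit of > 10 ug/mL in this assay, at which 3 of the 3 values shown sit.

The compounds shown leave open how these three compare with one another, and which group on that aromatic carbon, if any, would give a number in this assay.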